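The source may hold more compounds than are shown below. What is called first, only, known or untested is meant among the compounds shown, and "the series" means these compounds.

Measured in a functional assay on K562 cells (Homo sapiens) for antiproliferative activity, read by MTT assay, with a stated time of 48 h; on this read-out higher numbers stand for weaker inhibition and lower numbers for stronger inhibition:
- compound 1 `CN(C)CCCn1c(N)c(-c2nc3ccccc3o2)c2nc(C#N)c(C#N)nc21`: 5900 nM
- compound 2 `CCN(CC)CCn1c(N)c(-c2nc3cc(Cl)ccc3[nH]2)c2nc(C#N)c(C#N)nc21`: > 50000 nM

For compound 2 the reading > 50000 nM is a limit of the assay and not a number.

Compound 3 `CN(C)CCCn1c(N)c(-c2nc3cc(Cl)ccc3[nH]2)c2nc(C#N)c(C#N)nc21` differs from compound 2 as follows: (dimethylamino)methyl in place of diethylamino on a saturated chain carbon, two bonds along the chain from an aromatic nitrogen. The chain thus changes from 2-(diethylamino)ethyl to 3-(dimethylamino)propyl. No measured step sizes this change. Compound 1, which also carries the 3-(dimethylamino)propyl chain, gives 5900 nM in this assay. A clear move toward stronger inhibition is therefore expected, with an at least 5.5-fold lower number from compound 2 to compound 3 (0.74 log units; beyond the scatter) as the estimated step. Compound 3 is estimated at 9000 nM, with an expected range of 2000 nM to 40000 nM.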

Compound 3, half-maximal inhibitory concentration: 10700 nM
Beside the measured number, compound 3's estimate is 1.2-fold (0.08 log units) below it, within the range that was stated.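

In this assay, the 3-(dimethylamino)propyl chain in place of 2-(diethylamino)ethyl on the shared core gives an at least 4.6-fold lower number from compound 2 to compound 3 (0.66 log units; beyond the scatter). The size of this step is only a bound, as compound 2 reads at a limit of the assay and not a number: the limit of > 50000 nM in this assay, at which 1 of the 3 values shown sits. With the 3-(dimethylamino)propyl chain held, 5-chloro-1H-benzimidazol-2-yl in place of 1,3-benzoxazol-2-yl gives a 1.8-fold higher number from compound 1 to compound 3 (0.26 log units; within the scatter), so this assay does not separate the two groups.

The step from compound 2 changes chain length and the alkyl groups on the amine together, and the compounds shown do not separate the two. Open, as far as these compounds go, is how a 2-(dimethylamino)ethyl or 3-(diethylamino)propyl chain would read.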